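The source may hold more compounds than are shown below. What is called first, only, known or untested is meant among the compounds shown, and "the series" means these compounds.

Compound 1 `CC1CCN(C2CCN(S(=O)(=O)c3ccc(C(C)(C)C)cc3)CC2)CC1` gives > 5000 nM in a functional assay on DLD-1 cells (Homo sapiens) for antiproliferative activity, read by CellTiter-Glo, with a stated time of 72 h; a higher number here means a weaker inhibitor, a lower number a stronger inhibitor.
Compound 2 `CC1CCN(C2CCN(S(=O)(=O)c3cccc(-c4ccc(Cl)cc4)c3)CC2)CC1` gives 15 nM in this assay.
Compound 3 `Cc1cc(C)c(S(=O)(=O)N2CCC(c3ccccc3)CC2)c(C)c1` gives > 5000 nM in this assay.

Compound 1 stands at the edge of what this assay can report: its value is a limit, not a number, so it is at best a weak inhibitor. Compound 3 likewise gives only a limit. Going by the values given here, compound 2 is the one compound with a number inside the working range. Two of the three values sit at the limit of > 5000 nM in this assay, at which 2 of the 3 values shown sit, so little can be said about the spread among the measured compounds.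

Compound 4 `CC1CCN(C2CCN(S(=O)(=O)c3ccc(-c4ccccc4)cc3)CC2)CC1` has not been measured. It differs from compound 1 in a single place: phenyl in place of tert-butyl on an aromatic carbon. Among the compounds with values here, no step between measured compounds that differ in one place is available, so the expectation rests on the values themselves. Compound 2, with 15 nM, shows that compounds on this core can reach strong inhibition. Compound 4 is therefore expected to be a clearly stronger inhibitor than compound 1, an expected step of an at least 16-fold lower number from compound 1 to compound 4 (1.22 log units; beyond the scatter), beyond the usual scatter. Compound 4 is estimated at 300 nM, with a range from 30 nM to 3000 nM.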

Compound 4, half-maximal inhibitory concentration: 258 nM
Compound 4: middle estimate off by 1.2-fold (0.07 log units), on the high side; low and high end bracket the measured number.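

Phenyl in place of tert-butyl on an aromatic carbon gives an at least 19-fold lower number from compound 1 to compound 4 (1.28 log units; beyond the scatter) in this assay, the first step on the shared core that can be read. The value of compound 1 is a limit and not a number, so this step has only a lower bound: the limit of > 5000 nM in this assay, at which 2 of the 4 values shown sit. Neither group carries a hydrogen-bond donor, a hydrogen-bond acceptor or a net charge, so reaching a measurable value at this place does not require adding any of these.

The compounds shown do not separate the effect of having an aromatic ring here from that of simply having a larger group. An amine, a carboxylic acid or a longer chain on this same carbon would show how much this place accepts beyond phenyl.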